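This account rests on a few compounds, and the source may have more. Where it says the series, first, only, none or still open, it means among the compounds named here.

Measured compounds:
- compound 1, `CCCCC[Se]c1nc([Se]CCCCC)c2cccnc2n1`: 15200 nM
- compound 2, `Nc1nc([SeH])nc2ncccc12`: 44300 nM

In a functional assay on HTB-54 cells (Homo sapiens) for cytotoxicity, read by MTT assay, with a stated time of 72 h (on this read-out higher numbers stand for weaker inhibition of growth and lower numbers for stronger inhibition of growth), compound 1 gives 15200 nM. In this assay compound 2 gives 44300 nM, the highest of the two numbers shown; its nearest neighbour is compound 1, whose number is lower by a margin that lies beyond the usual scatter of this measurement. Among the measured compounds shown here, no single-change step connects these two compounds, so their pair can only be read as two numbers side by side.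

Compound 3, `CCCCC[Se]c1nc(N)c2cccnc2n1`, has not been measured in this assay. It differs from compound 2 by pentyl in place of hydrogen on a selenium, in words pentyl in place of hydrogen on a selenium. For the measured compounds named here, compound 1 carries pentyl on both of its selenium atoms, and it is the only measured compound with that group, giving a rough bearing on where the pentyl-bearing compound 3 may land.

Against that background compound 3 is expected to give 22000 nM, with a range from 7000 nM to 55000 nM. The change from compound 2 to compound 3 is estimated as a 2.0-fold lower number from compound 2 to compound 3 (0.30 log units; within the scatter), a modest move toward the lower number of compound 1.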

Compound 3, concentration for 50% growth inhibition: 8780 nM
For compound 3 the middle estimate is 2.5-fold (0.40 log units) above the measured one, within the range that was stated.
By their numbers in this assay, from the lowest: compounds 3 and 1 (each within the scatter of the next); then compound 2.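

In this assay, among the compounds shown here, pentyl in place of hydrogen on a selenium whose other neighbour is an aromatic carbon gives a 5.0-fold lower number from compound 2 to compound 3 (0.70 log units; beyond the scatter), and this is the first single-change reading at this selenium, a step that lies beyond the usual scatter. The earlier pair could only be read as two numbers side by side, whereas this step ties a real difference to the pentyl group alone. The other step, one nitrogen atom in place of a group of 6 heavy atoms on an aromatic carbon, gives a 1.7-fold lower number from compound 1 to compound 3 (0.24 log units; within the scatter) and lies within the scatter, so compound 1 and compound 3 cannot be told apart here, and no information on why the pentyl group shifts the number is available.

Whether the size of the step depends on chain length remains open, since only hydrogen and pentyl are shown on this selenium, and a methyl group, a longer chain such as octyl or a benzyl group could each read differently. As far as these compounds go, it is also open how the aromatic carbon that carries the amine in compound 3 would respond to a hydroxyl group or a morpholine.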